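Three limits and a trifluoromethoxy analogue

The compounds below may be only part of what the source reports. "The series", "measured", "known", "first", "only" and "open" are said of these compounds alone.

Measured compounds:
compound 1 `COc1ccc(C#Cc2ccc(C(=O)N3CCC[C@@H](CO)C3)cc2)c(F)c1`: > 10000 nM
compound 2 `CSc1ccc(C#Cc2ccc(C(=O)N3CCC[C@@H](CO)C3)cc2)cc1`: > 10000 nM
compound 3 `COc1ccc(C#Cc2ccc(C(=O)N3CCC[C@@H](CO)C3)cc2)cc1F`: > 10000 nM

In a functional assay on TREX cells for negative allosteric modulation of metabotropic glutamate receptor 3 (Rattus norvegicus), read by calcium flux, with a stated time of 2.5 min (on this read-out lower numbers stand for stronger inhibition and higher numbers for weaker inhibition), each of these three values is a limit of the assay and not a number, (the limit of > 10000 nM in this assay, at which 3 of the 3 values shown sit). Compound 2 therefore stands only at a limit in this assay, with no measured number to place it against the others. The steps among the measured compounds are all unreadable for the same reason: a step that the two limits leave unreadable from compound 1 to compound 2, a step that the two limits leave unreadable from compound 1 to compound 3 and a step that the two limits leave unreadable from compound 2 to compound 3 give no size in either direction.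

Compound 4 `O=C(c1ccc(C#Cc2ccc(OC(F)(F)F)cc2)cc1)N1CCC[C@@H](CO)C1` differs from compound 2 in one place: trifluoromethoxy in place of methylsulfanyl on an aromatic carbon. For the measured compounds named here, no measured step bears on this change, and the three steps among compound 1, compound 2 and compound 3 show only that three variations of the group on the triple-bonded carbon left every value at the limit. With nothing pointing to a readable number, compound 4 is expected to remain at or near the limit as well. The estimate for compound 4 in this assay is 15000 nM, within 5000 nM to 50000 nM. The expected step from compound 2 to compound 4, a step that the limit leaves unreadable from compound 2 to compound 4, is therefore no more than a guess toward no change.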

Compound 4, half-maximal inhibitory concentration: > 10000 nM
Compound 4: only a limit was reported; the forecaster's own chance of this, stated with the estimate: 75%; the middle value does not contradict the limit.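

In this assay no step can be read from compound 2 to compound 4, since each of the two stands only at a limit and not at a number: the limit of > 10000 nM in this assay, at which 4 of the 4 values shown sit.

The compounds shown leave open how strongly any of compound 1, compound 2, compound 3 and compound 4 inhibits, and whether the group on the triple-bonded carbon changes that at all.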